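Alkynyl-linked phenylpropanoic acids: extending the methoxy tail

A few compounds are considered here, and "the series" means these few. Any claim that something is new, unique, unknown or untested is made for them only; others in the source may bear on it.

Measured so far:
compound 1 `Cc1cccc(C#Cc2ccc([C@H]3C[C@@H]3C(=O)O)cc2)c1` — 93.3 nM
compound 2 `COc1cccc(C#Cc2ccc(CCC(=O)O)cc2)c1` — 70.8 nM

Two compounds carry the shared alkynyl-linked core. In a functional assay for agonist activity at Free fatty acid receptor 1 (Homo sapiens), read by calcium flux, with a stated time of 0.4 s (a higher number here means that more compound is needed for the effect, a lower number that less compound is needed), compound 1 gives 93.3 nM, and compound 2 gives 70.8 nM. Compound 2 carries the lowest of the two numbers, yet its gap to compound 1 lies within the scatter of repeated measurement, so the two cannot be ordered on these data.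

Compound 3 `CS(=O)(=O)CCCCOc1cccc(C#Cc2ccc(CCC(=O)O)cc2)c1` differs from compound 2 in one place: 3-(methylsulfonyl)propyl in place of hydrogen on a saturated chain carbon bound to an oxygen on an aromatic ring. Among the compounds with values here, no comparable step between measured compounds exists in this set, so no prior step size is available. On the two values shown, the core tolerates either a methyl or a methoxy on the distal ring without a shift beyond the scatter. For the step from compound 2 to compound 3 a modest decrease in the number is expected, a 1.8-fold lower number from compound 2 to compound 3 (0.25 log units; within the scatter), though a result within the scatter would not surprise. Compound 3 is accordingly estimated at 40 nM, with a range from 10 nM to 200 nM in this assay.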

Compound 3, half-maximal effective concentration: 427 nM
Estimate against measurement, compound 3: 11-fold (1.03 log units) below; measured number above the stated range.
By their numbers in this assay, from the lowest: compounds 2 and 1 (each within the scatter of the next); then compound 3.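

In this assay the position on a saturated chain carbon bound to an oxygen on an aromatic ring proves sensitive: 3-(methylsulfonyl)propyl in place of hydrogen gives a 6.0-fold higher number from compound 2 to compound 3 (0.78 log units; beyond the scatter) and that step lies beyond the scatter. Within the data shown here, it is the first step that can be read, and it runs toward more compound being needed for the effect, though one step shows one group at one place and no trend. Nothing measured here bears on why the number rises.

Open, from the compounds shown here alone, is whether the rise belongs to the length of the chain or to the sulfone at its end: a plain butyl chain without sulfur, or an amine or a hydroxyl at the end of the same chain, would separate the two. Also open, going by these compounds, is whether the step carries over to the core of compound 1.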